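From a dichlorophenyl arm to a carbamoylphenyl arm

The compounds below may be only part of what the source reports. "The series", "measured", "known", "first", "only" and "open" are said of these compounds alone.

Compound 3 `CCCS(=O)(=O)Nc1ccc(F)c(C(=O)c2n[nH]c3ncc(-c4ccc(Cl)c(Cl)c4)cc23)c1F` gives 45% in an assay for binding affinity to dual specificity mitogen-activated protein kinase kinase 4 (Homo sapiens), read by KINOMEscan, tested at 100 nM (on this read-out higher numbers stand for a weaker effect at the one concentration tested and lower numbers for a stronger effect), the highest of the three numbers at hand and therefore the weakest binder among them. Compound 1 `CCCS(=O)(=O)Nc1ccc(F)c(C(=O)c2n[nH]c3ncc(-c4ccccc4Cl)cc23)c1F` gives 9.3% and compound 2 `CCCS(=O)(=O)Nc1ccc(F)c(C(=O)c2n[nH]c3ncc(-c4ccc(C)cc4)cc23)c1F` gives 5.4%. Compound 4 `CCCS(=O)(=O)Nc1ccc(F)c(C(=O)c2n[nH]c3ncc(-c4ccc(C(N)=O)cc4)cc23)c1F` differs from compound 3 in one place: 4-carbamoylphenyl in place of 3,4-dichlorophenyl on an aromatic carbon. Among the compounds with values here, two measured steps bear on this change, since both end at the 3,4-dichlorophenyl group that now leaves: a number 35.7 percentage points higher from compound 1 to compound 3 (beyond the scatter) and a number 39.6 percentage points higher from compound 2 to compound 3 (beyond the scatter). Within the data shown here, both were large rises, so taking that group away is expected to bring the number back down by a large step, although the entering group is new and no step involving it has been measured. For compound 4 the expected step is a number 30 percentage points lower from compound 3 to compound 4 (beyond the scatter), giving an estimated value of 15% within a range from 3% to 50%.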

Compound 4, a percentage reported as activity, at one concentration (the size of the read-out at that concentration, not a potency): 0.15%
For compound 4 the middle estimate is 14.9 percentage points above the measured one, and the stated range ends above it.
By their numbers in this assay, from the lowest: compounds 4, 2 and 1 (each within the scatter of the next); then compound 3.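

At this position, an arm carrying nitrogen and oxygen, with a hydrogen-bond donor and acceptor, is accepted in this assay: 4-carbamoylphenyl gives a number 44.9 percentage points lower from compound 3 to compound 4 (beyond the scatter). It joins the 4-methylphenyl and 2-chlorophenyl arms, with a number 5.3 percentage points lower from compound 2 to compound 4 (within the scatter) and a number 9.2 percentage points lower from compound 1 to compound 4 (within the scatter), leaving only 3,4-dichlorophenyl apart from the others. Nothing measured here explains why that arm differs. On these data alone, it remains open whether a carboxylic acid or an amine in place of the carbamoyl would also stay with the low numbers.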